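This account rests on a few compounds, and the source may have more. Where it says the series, first, only, none or still open, it means among the compounds named here.

In a functional assay on MKN-45 cells (Homo sapiens) for cytotoxicity, read by MTT assay, with a stated time of 48 h (a lower number here means a stronger inhibitor, a higher number a weaker inhibitor), compound 1 `C#CCSc1nnc(C)n1N1C(=O)c2ccccc2C1=O` returns only the limit of the assay, > 200000 nM. Compound 2 `CCOC(=O)CSc1nnc(CC)n1N1C(=O)c2ccccc2C1=O` likewise stops at the limit, > 200000 nM. Compound 3 `C#CCSc1nnc(-c2cc(OC)c(OC)c(OC)c2)n1N1C(=O)c2ccccc2C1=O` also gives no number but the limit > 200000 nM, so its standing among the three cannot be placed any further than the note that (the limit of > 200000 nM in this assay, at which 3 of the 3 values shown sit). Compound 4 `COc1cc(-c2nnc(SC)n2N2C(=O)c3ccccc3C2=O)cc(OC)c1OC` differs from compound 3 by hydrogen in place of ethynyl on a saturated chain carbon bound to a sulfur. Going by the values given here, no measured step is available for this change, so no direction can be read from the numbers. The step that the limit leaves unreadable from compound 3 to compound 4 is expected to stay within the scatter. Compound 4 is therefore expected to give 250000 nM, within a range from 60000 nM to 1000000 nM, most likely again reported only as a limit.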

Compound 4, half-maximal inhibitory concentration: > 200000 nM
Compound 4: only a limit was reported; the forecaster's own chance of this, stated with the estimate: 85%; the middle value is on the limit's open side.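

Compound 3 and compound 4 both stop at the assay's limit, so no step can be read between them: the limit of > 200000 nM in this assay, at which 4 of the 4 values shown sit. From the compounds shown here alone, whether any change to the shared core would give a measured number rather than a limit stays open.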